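The compounds below may be only part of what the source reports. "The series", "measured", "known", "first", "only" and "open" are said of these compounds alone.

In a functional assay on A549 cells (Homo sapiens) for inhibition, read by MTT assay, with a stated time of 72 h (on this read-out higher numbers stand for weaker inhibition and lower numbers for stronger inhibition), compound 1 `COc1ccc(-c2cc(=O)oc3ccc(F)cc23)cc1O` gives 1500 nM, and compound 2 `COc1ccc(-c2cc(=O)oc3ccc(C)cc23)cc1O` gives 200 nM. Compound 3 `COc1ccc(-c2cc(=O)oc3ccc(F)cc23)cn1` reads > 80000 nM, which is a limit and not a number. That reading is the limit of > 80000 nM in this assay, at which 1 of the 3 values shown sits.

Compound 4 `COc1ccc(-c2cc(=O)oc3ccccc23)cn1` carries hydrogen in place of fluoro on an aromatic carbon. Among the measured compounds shown here, the only measured step that also replaces this fluoro is a 7.5-fold lower number from compound 1 to compound 2 (0.88 log units; beyond the scatter), a modest change beyond the scatter, with methyl in place of fluoro on an aromatic carbon. It points towards a lower number once the fluoro leaves, but hydrogen is not methyl, and that step starts from a compound with a far lower reading. Since compound 3 has no number, the size of the step from it can only be judged loosely. In this assay, a modest move to a lower number is expected, and compound 4 may well stay at the limit.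

The expected step is an at least 1.6-fold lower number from compound 3 to compound 4 (0.20 log units; that floor lies within the scatter). Compound 4 is estimated at 50000 nM, with an expected range from 10000 nM to 150000 nM.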

Compound 4, half-maximal inhibitory concentration in the A549 assay: 41000 nM
Compound 4: the middle estimate sits 1.2-fold (0.09 log units) above what was measured; the range from low to high includes it.
By their numbers in the A549 assay, from the lowest: compound 2; then compound 1; then compound 4. At a limit, above all of these: compound 3.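

Removing the fluoro from this aromatic carbon gives a second reading at this position, now on the core of compound 3, and in the A549 assay the change to hydrogen gives an at least 1.9-fold lower number from compound 3 to compound 4 (0.29 log units; that floor lies within the scatter). Its direction in the A549 assay matches a 7.5-fold lower number from compound 1 to compound 2 (0.88 log units; beyond the scatter), but compound 3 holds only a limit and not a number, so the true size of the step stays unknown: the limit of > 80000 nM in the A549 assay, at which 1 of the 4 values shown sits.

In a physicochemical assay for solubility, in phosphate buffer, with a stated time of 2 h, at pH 7.4 (a lower number here means a less soluble compound, a higher number a more soluble compound), compound 3 gives 80000 nM and compound 4 gives 80000 nM. In the physicochemical assay the same change gives no change at the digits printed from compound 3 to compound 4 (within the scatter).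

The compounds shown leave open whether methyl on the core of compound 3 would lower the number as it does from fluoro on the core of compound 1. They also leave open how an amine or a longer chain on this aromatic carbon would read in the A549 assay.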